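The source may report more compounds than this note shows. Statements on the series, on what has been measured and on what is new or still open speak of the compounds shown alone.

The measured compounds:
compound 1, `Cc1cnn(C(=O)N(C)CCN(C)Cc2cccc(OCc3ccccc3)c2)c1`, 8300 nM
compound 2, `CN(CCN(C)C(=O)n1cccn1)Cc1cccc(OCc2ccccc2)c1`, 5500 nM
compound 3, `Cc1cnn(C(=O)N2CCN(C(c3ccc(OCc4ccccc4)cc3)c3ccc(OCc4ccccc4)cc3)CC2)c1`, > 100000 nM

All three were tested in an assay on membranes from brain for binding affinity to Monoacylglycerol lipase ABHD6 (Mus musculus), read by fluorescence, with stated times of 1 h and 30 min; a higher number here means a weaker inhibitor, a lower number a stronger inhibitor. Compound 1 gives 8300 nM, and compound 2 gives 5500 nM. These two share a core and differ only by hydrogen in place of methyl on an aromatic carbon, a change that made a 1.5-fold lower number from compound 1 to compound 2 (0.18 log units; within the scatter). For compound 3 the assay reports only a limit, > 100000 nM, so no exact number is known for it. Compound 3 is built on a different core from compound 1, and the difference between the two cores is not broken down here. Compound 4, `O=C(N1CCN(C(c2ccc(OCc3ccccc3)cc2)c2ccc(OCc3ccccc3)cc2)CC1)n1cccn1`, has not yet been measured; it differs from compound 3 by hydrogen in place of methyl on an aromatic carbon, the same change as from compound 1 to compound 2, made at the same place. With that change having produced only a 1.5-fold lower number from compound 1 to compound 2 (0.18 log units; within the scatter) in the first pair, and with the starting point here being a limit (the limit of > 100000 nM in this assay, at which 1 of the 3 values shown sits), the expected step is a step that the limit leaves unreadable from compound 3 to compound 4. In this assay compound 4 is therefore estimated at 120000 nM, with a likely range from 40000 nM to 400000 nM, and a real chance that it again reads only as a limit.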

Compound 4, half-maximal inhibitory concentration: > 100000 nM
Compound 4: only a limit was reported; the forecaster's own chance of this, stated with the estimate: 75%; the middle value is on the limit's open side.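

Compound 4 reads > 100000 nM, which is a limit and not a number. For the compounds shown here, compound 3 also reads only as a limit, and no step from compound 3 to compound 4 can be read. Still open, on these data alone, is whether changing 4-methyl-1H-pyrazol-1-yl to 1H-pyrazol-1-yl has any effect on the core these two compounds share.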